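The source may report more compounds than this note shows. Statements on the series, on what has been measured and on what is new or still open speak of the compounds shown alone.

Measured so far in a functional assay (blood) for inhibition, with Homo sapiens as the target; a higher number here means a weaker inhibitor, a lower number a stronger inhibitor:
- compound 1 `CC(C)(C)Sc1c(CC(C)(C)C(=O)O)n(Cc2ccc(Cl)cc2)c2ccc(OCc3ccc4cc(F)c(F)cc4n3)cc12`: in this assay compound 1 gives > 3000 nM, a limit of the assay rather than a number.
- compound 2 `CC(C)(C)Sc1c(CC(C)(C)C(=O)O)n(Cc2ccc(Cl)cc2)c2ccc(OCc3ccc4cccnc4n3)cc12`: in this assay compound 2 gives > 3000 nM, again a limit.
- compound 3 `CC(COc1ccc2c(c1)c(SC(C)(C)C)c(CC(C)(C)C(=O)O)n2Cc1ccc(Cl)cc1)c1ccccn1`: in this assay compound 3 gives 270 nM.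

Compound 2 therefore stands only at the limit of > 3000 nM in this assay, at which 2 of the 3 values shown sit, and its true number is not known.

Compound 4 `CC(C)(C)Sc1c(CC(C)(C)C(=O)O)n(Cc2ccc(Cl)cc2)c2ccc(OCc3cnccn3)cc12` differs from compound 2 by a group of 6 heavy atoms (4 carbon, 2 nitrogen; one six-membered aromatic ring with 2 hetero atoms) in place of a group of 10 heavy atoms (8 carbon, 2 nitrogen; 2 six-membered aromatic rings with 1 hetero atom each), on a saturated chain carbon bound to an oxygen on an aromatic ring.

The step that bears on this is an at least 11-fold lower number from compound 2 to compound 3 (1.04 log units; beyond the scatter), where a group with one six-membered aromatic ring with one hetero atom also replaced the two-ring group; a step that the two limits leave unreadable from compound 1 to compound 2 adds nothing readable. A lower number is therefore expected for compound 4, its size uncertain since the entering ring carries two hetero atoms. The step expected from compound 2 to compound 4 is an at least 3.3-fold lower number from compound 2 to compound 4 (0.52 log units; beyond the scatter). Compound 4 is estimated at 900 nM, between 200 nM and 4000 nM.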

Compound 4, half-maximal inhibitory concentration: 400 nM
Beside the measured number, compound 4's estimate is 2.3-fold (0.35 log units) above it; low and high end bracket the measured number.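

In this assay pyrazin-2-yl in place of the two-ring groups gives an at least 7.5-fold lower number from compound 2 to compound 4 (0.87 log units; beyond the scatter) and an at least 7.5-fold lower number from compound 1 to compound 4 (0.87 log units; beyond the scatter) as a second case, after compound 3, of a one-ring group on the saturated chain carbon doing better than those two-ring groups. The step of a 1.5-fold higher number from compound 3 to compound 4 (0.17 log units; within the scatter) leaves pyrazin-2-yl and 1-(pyridin-2-yl)ethyl level, so a ring with two hetero atoms serves here as well.

As far as these compounds go, the true size of the gain stays open, as compound 2 holds only a limit of the assay: the limit of > 3000 nM in this assay, at which 2 of the 4 values shown sit. From the compounds shown here alone, whether a plain phenyl ring or an amine at this place would do as well also remains open.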